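The compounds below may be only part of what the source reports. "The series", "measured", "known", "first", "only" and "open" are said of these compounds alone.

Measured so far:
Compound 1, `COc1ccc(-c2cc3nccc(-c4cc(OC)c(OC)c(OC)c4)n3n2)cc1F`, gives 183 nM in a functional assay on MCF7 cells (Homo sapiens) for inhibition, read by CCK-8 assay, with a stated time of 48 h; on this read-out higher numbers stand for weaker inhibition and lower numbers for stronger inhibition.
Compound 2, `COc1cc(-c2ccnc3cc(-c4ccc(N(C)C)cc4)nn23)cc(OC)c1OC`, gives 44 nM.
Compound 3, `COc1cc(-c2ccnc3cc(-c4ccc(C(F)(F)F)cc4)nn23)cc(OC)c1OC`, gives 2440 nM.

Compound 3 stands highest of the three numbers. Its nearest neighbour is compound 1, reached by a 13-fold higher number from compound 1 to compound 3 (1.12 log units; beyond the scatter), and its furthest is compound 2, reached by a 55-fold higher number from compound 2 to compound 3 (1.74 log units; beyond the scatter). Both steps lie beyond the scatter, so the trifluoromethyl-bearing aryl of compound 3 is the weakest inhibitor among the three measured compounds.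

Compound 4, `C=Cc1ccc(-c2cc3nccc(-c4cc(OC)c(OC)c(OC)c4)n3n2)cc1`, is not yet measured. It differs from compound 3 in one place: vinyl in place of trifluoromethyl on an aromatic carbon. Among the measured compounds shown here, two measured steps bear on this change, since both exchange the same group on the same aromatic carbon. Going from compound 2 to compound 3 was a large rise in the number, and going from compound 1 to compound 3 was also large; the data hold no step in which vinyl itself enters, so the size it would give cannot be read directly. The shared pattern is that every measured alternative to trifluoromethyl gave a lower number. Compound 4 is therefore expected to show a drop from compound 3 of a 3.5-fold lower number from compound 3 to compound 4 (0.54 log units; beyond the scatter), smaller than either measured step. The estimate for compound 4 in this assay is 700 nM, between 180 nM and 2700 nM.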

Compound 4, half-maximal inhibitory concentration: 193 nM
Estimate against measurement, compound 4: 3.6-fold (0.56 log units) above, within the range that was stated.
By their numbers in this assay, from the lowest: compound 2; then compounds 1 and 4 (each within the scatter of the next); then compound 3.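

In this assay, the place on the aromatic carbon para to a large group responds strongly to a change between two groups that look alike in their counts: vinyl in place of trifluoromethyl gives a 13-fold lower number from compound 3 to compound 4 (1.10 log units; beyond the scatter) even though neither group has hydrogen-bond donors or acceptors and neither carries a net charge, so those counts do not separate the two. Vinyl is the first entering group here without a heteroatom, yet it does not match dimethylamino, as a 4.4-fold higher number from compound 2 to compound 4 (0.64 log units; beyond the scatter) shows, while a 1.1-fold higher number from compound 1 to compound 4 (0.02 log units; within the scatter) leaves 4-vinylphenyl and 3-fluoro-4-methoxyphenyl indistinguishable on this read-out, so two quite different aryl groups give the same level of inhibition. Nothing among the data shown accounts for any of these differences.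

The compounds shown leave open whether the double bond of vinyl matters, which ethyl on the same aromatic carbon would address. They also leave open how much of the standing of dimethylamino belongs to its nitrogen and how much to its two methyl groups, a question that a primary amine or a morpholine ring in that place would bear on.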